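The compounds below may be only part of what the source reports. "The series", "measured", "known", "first", "only" and "open" are said of these compounds alone.

Compound 1 `CC(C)Cn1cc(-c2cc(Nc3ccc(OC(F)(F)F)cc3)ncn2)cn1` gives > 10000 nM in an ADME assay on BaF3 cells (Mus musculus) for cytotoxicity (a lower number here means that less compound is needed, a higher number that more compound is needed for the effect), a limit of the assay and not a number. Compound 2 `NC(=O)CCn1ccc2c(Nc3ccc(OC(F)(F)F)cc3)ncnc21` gives > 10000 nM in this assay, again a limit. Compound 3 `NS(=O)(=O)c1ccc(-c2cc(Nc3ccc(OC(F)(F)F)cc3)ncn2)cc1` gives > 10000 nM in this assay, also a limit.

Compound 1 therefore stands nowhere in particular among these three: all that is known of it in this assay is the limit of > 10000 nM in this assay, at which 3 of the 3 values shown sit, and the same holds for compound 2 and compound 3, so no order among them can be drawn.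

The step to compound 4 `FC(F)(F)Oc1ccc(Nc2cc(-n3ccnc3)ncn2)cc1` is 1H-imidazol-1-yl in place of 1-isobutyl-1H-pyrazol-4-yl on an aromatic carbon. No measured step between any two of these compounds exists, so there is no comparison to lean on. Since compound 1 reaches only a limit, the step expected in this assay from compound 1 to compound 4 is a step that the limit leaves unreadable from compound 1 to compound 4, that is, none beyond the scatter. Compound 4 is thus estimated at 15000 nM in this assay, with a range from 5000 nM to 50000 nM, and most likely it will again be reported only as a limit.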

Compound 4, half-maximal effective concentration: > 10000 nM
Compound 4: only a limit was reported (the forecaster's own chance of this, stated with the estimate: 85%); the middle value does not contradict the limit.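

In this assay compound 4 gives > 10000 nM, a limit of the assay and not a number, so no step from compound 1 to compound 4 can be read: the limit of > 10000 nM in this assay, at which 4 of the 4 values shown sit.

The compounds shown leave open at what concentration, if any, any of them would reach the effect in this assay, and whether 1H-imidazol-1-yl in place of 1-isobutyl-1H-pyrazol-4-yl changes it.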